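Piperazine group swap on the shared core: compound 2 to compound 3

A few compounds are considered here, and "the series" means these few. Any claim that something is new, unique, unknown or untested is made for them only; others in the source may bear on it.

In an ADME assay for permeability, using PAMPA, at pH 7.4 (on this read-out lower numbers stand for lower permeability and higher numbers for higher permeability), compound 1 `C[C@@H]1CN(c2cccc3c2C[C@H](CN(C)[C@H]2CCCc4cccnc42)NC3)C[C@H](C)N1` gives 39 nm/s and compound 2 `CC(C)N1CCN(c2cccc3c2C[C@H](CN(C)[C@H]2CCCc4cccnc42)NC3)CC1` gives 143 nm/s as the higher of the two numbers. Compound 3 `CN(C[C@H]1Cc2c(cccc2N2CCN3CCC[C@@H]3C2)CN1)[C@H]1CCCc2cccnc21` carries a group of 9 heavy atoms (7 carbon, 2 nitrogen; one five-membered non-aromatic ring with 1 hetero atom, one six-membered non-aromatic ring with 2 hetero atoms) in place of a group of 9 heavy atoms (7 carbon, 2 nitrogen; one six-membered non-aromatic ring with 2 hetero atoms), on an aromatic carbon relative to compound 2. Among the compounds with values here, the only measured step bearing on this is a 3.7-fold higher number from compound 1 to compound 2 (0.56 log units; beyond the scatter) as a modest change beyond the scatter, also on an aromatic carbon. Within the data shown here, no measured compound carries the entering group, so that single step is the only guide. A smaller, downward change is expected in this assay with a 1.3-fold lower number from compound 2 to compound 3 (0.11 log units; within the scatter) as the estimated step, probably within the scatter. Compound 3 is estimated at 110 nm/s within a range of 45 nm/s to 260 nm/s for four of five measurements.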

Compound 3, apparent permeability: 740 nm/s
For compound 3 the middle estimate is 6.7-fold (0.83 log units) below the measured one; measured number above the stated range.
By their numbers in this assay, from the lowest: compound 1; then compound 2; then compound 3.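

In this assay, swapping 4-isopropylpiperazin-1-yl for the group with one five-membered and one six-membered non-aromatic ring gives a 5.2-fold higher number from compound 2 to compound 3 (0.71 log units; beyond the scatter) even though heavy atoms, donors, acceptors and net charge count the same in both groups. Set against 3,5-dimethylpiperazin-1-yl, the same entering group gives a 19-fold higher number from compound 1 to compound 3 (1.28 log units; beyond the scatter) as the largest step seen on this aromatic carbon. No measurement at hand accounts for either step.

Still open, as far as these compounds go, is whether the opposite stereoisomer of the entering group would keep this high number. A morpholine or a plain dimethylamino group on the same aromatic carbon would show how far the trend reaches beyond piperazine-type groups.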